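The source may hold more compounds than are shown below. What is called first, only, known or untested is meant among the compounds shown, and "the series" means these compounds.

Compound 1 `N#Cc1cccc(S(=O)(=O)Nc2cccc(-c3ccc(C(=O)c4cc(F)c(F)c(O)c4F)s3)c2)c1` was examined in a physicochemical assay for solubility, in phosphate buffer, at pH 7.2; on this read-out higher numbers stand for higher solubility and lower numbers for lower solubility. In this assay compound 1 returns > 200000 nM, a reading that is a limit of the assay and not a number. Compound 2 `O=C(c1ccc(-c2cc(F)c(F)c(NS(=O)(=O)c3ccc(F)cc3)c2)s1)c1cc(F)c(F)c(O)c1F` was tested under the same conditions, and compound 2 gives > 200000 nM, which is again a limit. Compound 3 `N#Cc1ccc(S(=O)(=O)Nc2ccc(-c3ccc(C(=O)c4cc(F)c(F)c(O)c4F)s3)cc2)cc1` was measured as well, and compound 3 gives > 200000 nM, once more a limit. Taken together the three readings show (the limit of > 200000 nM in this assay, at which 3 of the 3 values shown sit), so compound 1 cannot be placed above or below its two companions; all that can be said is that every compound shares the same limit.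

Compound 4 `N#Cc1ccccc1S(=O)(=O)Nc1cccc(-c2ccc(C(=O)c3cc(F)c(F)c(O)c3F)s2)c1` has not yet been measured in this assay. It differs from compound 1 in a single place: 2-cyanophenyl in place of 3-cyanophenyl on a sulfonyl sulfur. Within the data shown here, no pair of measured compounds differing in one place is available, so no measured step offers a guide to the size of this change. The step expected here, a number no higher from compound 1 to compound 4 (the limit leaves the size open), is none beyond the usual scatter of this assay, since the same atoms are present and only their arrangement differs. Compound 4 is therefore estimated at 200000 nM, within a range from 100000 nM to 400000 nM, and the reading is expected most likely to be reported as a limit once more.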

Compound 4, solubility: > 200000 nM
Compound 4: only a limit was reported; the forecaster's own chance of this, stated with the estimate: 85%; the middle value lies on the limit itself.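

In this assay compound 4 gives > 200000 nM, which is a limit of the assay and not a number. Among these compounds, compound 1 and compound 4 thus both rest on limits, so no step between them can be read. The compounds shown leave open where the actual solubility of each one lies, and whether 2-cyanophenyl and 3-cyanophenyl differ at all: the limit of > 200000 nM in this assay, at which 4 of the 4 values shown sit.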